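The source may hold more compounds than are shown below. What is called first, only, known or untested is meant among the compounds shown, and "the series" means these compounds.

Measured compounds in a functional assay on HL-60 cells (Homo sapiens) for antiproliferative activity, read by sulforhodamine B assay, with a stated time of 72 h; a higher number here means a weaker inhibitor, a lower number a stronger inhibitor:
- compound 1 `COc1cccc(NC(=S)N/N=C/c2ccc3ccccc3n2)c1`: 71200 nM
- compound 2 `CN(C)C(=S)N/N=C/c1cnc2ccccc2n1`: 90 nM
- compound 3 `Cc1ccc(NC(=O)N/N=C/c2ccc3ccccc3n2)cc1`: > 100000 nM

Compound 1 stands at the highest of the two numbers shown in this assay. The nearest number is that of compound 2, which lies far lower, well beyond the scatter. Compound 3 gives no number in this assay, only a limit, (the limit of > 100000 nM in this assay, at which 1 of the 3 values shown sits). Going by the values given here, no step between compounds that differ in one place has been measured, so there is no computed step to lean on.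

Compound 4 `Cc1ccc(NC(=S)N/N=C/c2ccc3ccccc3n2)cc1` is the next compound to be measured. It differs from compound 1 as follows: 4-methylphenyl in place of 3-methoxyphenyl on an amide-type nitrogen. The change keeps the shared core and the thiocarbonyl, and swaps one ring for another of much the same size. Given the position of compound 1 in this assay, the expected step of a 1.0-fold lower number from compound 1 to compound 4 (0.01 log units; within the scatter) is none beyond the scatter, with some chance that compound 4 ends at the limit instead. Compound 4 is expected to give about 70000 nM in this assay, with a range from 25000 nM to 150000 nM.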

Compound 4, half-maximal inhibitory concentration: 78300 nM
Compound 4: middle estimate off by 1.1-fold (0.05 log units), on the low side; the range from low to high includes it.
By their numbers in this assay, from the lowest: compound 2; then compounds 1 and 4 (each within the scatter of the next). At a limit, above all of these: compound 3.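

In this assay, 4-methylphenyl in place of 3-methoxyphenyl on the amide-type nitrogen gives a 1.1-fold higher number from compound 1 to compound 4 (0.04 log units; within the scatter). This first measured step shows that, at this position with the thiocarbonyl kept, the two substituted phenyl rings cannot be told apart, even though the methoxy oxygen is lost. Compound 3, which carries a carbonyl where compound 4 carries the thiocarbonyl, gives no number, only a limit: the limit of > 100000 nM in this assay, at which 1 of the 4 values shown sits.

Compound 2 differs from compound 1 and compound 4 in more than one place, so its much lower number cannot be assigned to any single change. As far as these compounds go, whether a piperidine or a carboxylic acid-bearing ring on this nitrogen would move the number also remains open.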